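A Basic Side Chain on a Long-Lived Compound

This account rests on a few compounds, and the source may have more. Where it says the series, first, only, none or still open, it means among the compounds named here.

Compound 1 `CN/C(=N\C1=NC(=O)C(=O)N1C(C)C)Nc1ccc(Cl)c(Cl)c1` is tested in an in vitro ADME assay on microsomes from liver (Mus musculus) for metabolic stability, read by LC-MS; a lower number here means that the compound disappears faster, a higher number that the compound lasts longer. There compound 1 gives > 1 h, which is a limit. Compound 2 `CC(C)N/C(=N\C1=NC(=O)C(=O)N1C(C)C)Nc1ccc(Cl)c(Cl)c1` gives > 1 h, also a limit. Compound 3 `CC(C)N1C(=O)C(=O)N=C1/N=C(\NCc1ccccc1)Nc1ccc(Cl)c(Cl)c1` gives > 1 h, again a limit. All three results therefore sit together: the limit of > 1 h in this assay, at which 3 of the 3 values shown sit.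

Compound 4 `CC(C)N1C(=O)C(=O)N=C1/N=C(\NCCCN(C)C)Nc1ccc(Cl)c(Cl)c1` differs from compound 1 as follows: 2-(dimethylamino)ethyl in place of hydrogen on a saturated chain carbon bound to an amine nitrogen. Two measured changes bear on this one, a step that the two limits leave unreadable from compound 1 to compound 2 and a step that the two limits leave unreadable from compound 1 to compound 3, and neither gives a size. Nothing with a 2-(dimethylamino)ethyl group has been measured yet. No step beyond the usual scatter is therefore expected, in either direction, and the estimate is a step that the limit leaves unreadable from compound 1 to compound 4. For compound 4, the expected half-life is 1.2 h, within an estimated range of 0.5 h to 3 h.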

Compound 4, half-life: > 1 h
Compound 4 ended at the assay's limit; the forecaster's own chance of this, stated with the estimate: 60%; the middle value does not contradict the limit.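

Among the compounds shown here, no step among compound 1, compound 2, compound 3 and compound 4 can be read, because each gives only a limit: the limit of > 1 h in this assay, at which 4 of the 4 values shown sit.

The actual half-life of each of these compounds in this assay stays open, and with it any difference between them.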